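Methoxy Substitution and Tolerance in Vero Cells

The source may hold more compounds than are shown below. What is called first, only, known or untested is meant among the compounds shown, and "the series" means these compounds.

Measured compounds and their values in an ADME assay on Vero cells (Chlorocebus sabaeus) for cytotoxicity, read by fluorescence and resazurin assay, with a stated time of 72 h; a lower number here means that less compound is tolerated, a higher number that more compound is tolerated:
compound 1 `CC1=CSC2=NC(/C=C/c3ccccc3)=C(C(=O)/C=C/c3ccccc3)C(c3ccccc3)N12` gives 195 ug/mL
compound 2 `CC1=CSC2=NC(/C=C/c3ccc(Cl)cc3)=C(C(=O)/C=C/c3ccc(Cl)cc3)C(c3ccccc3)N12` gives 252 ug/mL
compound 3 `COc1ccc(C2C(C(=O)/C=C/c3ccccc3)=C(/C=C/c3ccccc3)N=C3SC=C(C)N32)cc1` gives 211 ug/mL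

Compound 3 differs from compound 1 by methoxy in place of hydrogen on an aromatic carbon, and this change made a step of a 1.1-fold higher number from compound 1 to compound 3 (0.03 log units; within the scatter). The three values lie close together, and the difference between the core of compound 1 and the core of compound 2 is not broken down here.

Compound 4 `COc1ccc(C2C(C(=O)/C=C/c3ccc(Cl)cc3)=C(/C=C/c3ccc(Cl)cc3)N=C3SC=C(C)N32)cc1` has not been measured in this assay. Among the measured compounds shown here, it differs from compound 2 by methoxy in place of hydrogen on an aromatic carbon, the same change as the one from compound 1 to compound 3, since the place is described in identical words for both pairs. Because the earlier step of this change, a 1.1-fold higher number from compound 1 to compound 3 (0.03 log units; within the scatter), stayed within the scatter, the step from compound 2 to compound 4 is expected to be of similar size, namely a 1.1-fold higher number from compound 2 to compound 4 (0.03 log units; within the scatter). On this basis compound 4 is estimated to give 270 ug/mL in this assay, with a likely range from 170 ug/mL to 420 ug/mL.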

Compound 4, half-maximal cytotoxic concentration: 273 ug/mL
Compound 4: the middle estimate sits 1.0-fold (0.00 log units) below what was measured; measured number inside the range.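

In this assay, the change from phenyl to 4-methoxyphenyl gave a 1.1-fold higher number from compound 2 to compound 4 (0.03 log units; within the scatter), and the step matches the earlier one on the other core: the same change on two cores in this assay, a 1.1-fold higher number (0.03 log units; within the scatter) from compound 1 to compound 3 and a 1.1-fold higher number (0.03 log units; within the scatter) from compound 2 to compound 4, 1.0-fold (0.00 log units) apart, within the scatter of two such steps. Across these two cores, then, the change carried over with no step beyond the scatter, and the two steps cannot be told apart. This does not show that methoxy has a real effect of its own on the tolerated concentration, as each step alone stays within the scatter, and two cores cannot show how the change would behave on a third.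

The compounds shown leave open whether a group other than methoxy at this place, such as an amine, a carboxylic acid or a longer alkoxy chain, would also leave the number within the scatter. They also leave open whether methoxy would behave the same way on an aromatic ring other than the one changed here.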